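The source may report more compounds than this note shows. Statements on the series, on what has been measured and on what is new or still open speak of the compounds shown alone.

compound 1 `Cc1cc(=O)c2c(O)c(CN(C(C)C)C(C)C)c(O)c([C@H]3CCN(C)C[C@H]3O)c2o1`: 21%
compound 2 `Cc1cc(=O)c2c(O)c(CN3CCCC3C(=O)O)c(O)c([C@H]3CCN(C)C[C@H]3O)c2o1`: 16%

For the measured compounds named here, in a functional assay on HL-60 cells (Homo sapiens) for inhibition, read by MTT assay, with a stated time of 48 h, tested at 10 uM (a lower number here means less inhibition of growth, a higher number more inhibition of growth at the concentration tested), compound 2 gives 16% and stands within the scatter of compound 1, the only other compound measured. The next compound, compound 3 `Cc1cc(=O)c2c(O)c(CN3CCCCC3)c(O)c([C@H]3CCN(C)C[C@H]3O)c2o1`, keeps the shared core and has piperidin-1-yl in place of 2-carboxypyrrolidin-1-yl on a saturated chain carbon bound to an aromatic carbon. Going by the values given here, one measured step bears on this change. Putting 2-carboxypyrrolidin-1-yl in place of diisopropylamino at that same place gave a number 5 percentage points lower from compound 1 to compound 2 (within the scatter), a small step. Among the compounds with values here, no compound with piperidin-1-yl has been measured yet. What is expected in this assay is therefore a number 6 percentage points higher from compound 2 to compound 3 (within the scatter), with no shift beyond the scatter. For compound 3 the estimated value is 22%, with an expected range from 10% to 35% in this measurement.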

Compound 3, percent growth inhibition at one concentration: 32%
Compound 3: middle estimate off by 10 percentage points, on the low side; the range from low to high includes it.
By their numbers in this assay, from the lowest: compounds 2 and 1 (each within the scatter of the next); then compound 3.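

In this assay, the group on a saturated chain carbon bound to an aromatic carbon now proves able to move the growth inhibition beyond the scatter: piperidin-1-yl in place of 2-carboxypyrrolidin-1-yl gives a number 16 percentage points higher from compound 2 to compound 3 (beyond the scatter), and in place of diisopropylamino it gives a number 11 percentage points higher from compound 1 to compound 3 (beyond the scatter). Piperidin-1-yl thus stands apart from both earlier groups, which lie within the scatter of each other, and compound 3 ranks highest of the three, though both steps are modest. Nothing at hand says what lies behind this difference.

From the compounds shown here alone, it remains open whether the six-membered ring alone accounts for the result, as a plain pyrrolidin-1-yl or a piperidine ring bearing a carboxylic acid would separate ring size from the acid. Going by these compounds, how a morpholin-4-yl ring would read at this place also remains open.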